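Replacing methoxy with dimethylamino in the series

This account rests on a few compounds, and the source may have more. Where it says the series, first, only, none or still open, it means among the compounds named here.

Measured in a functional assay on P388 cells (Mus musculus) for inhibition; on this read-out lower numbers stand for stronger inhibition and higher numbers for weaker inhibition:
- compound 1 `O=C1/C(=C/c2ccc(Br)cc2)CCCc2ccccc21`: 18600 nM
- compound 2 `COc1ccc(/C=C2\CCCc3ccccc3C2=O)cc1`: 1600 nM

Of the two, compound 2 holds the lower number, at 1600 nM. Still unmeasured is compound 3 `CN(C)c1ccc(/C=C2\CCCc3ccccc3C2=O)cc1`, with dimethylamino in place of methoxy on an aromatic carbon. Among the compounds with values here, the only measured step, a 12-fold lower number from compound 1 to compound 2 (1.07 log units; beyond the scatter), is large, but it swaps bromo for methoxy and does not test dimethylamino. No step beyond the scatter is therefore expected in this assay, with a slight lean towards a lower number. The expected step is a 1.2-fold lower number from compound 2 to compound 3 (0.09 log units; within the scatter). The estimate for compound 3 is 1300 nM, within a range of 400 nM to 4500 nM.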

Compound 3, half-maximal inhibitory concentration: 1900 nM
Beside the measured number, compound 3's estimate is 1.5-fold (0.16 log units) below it; the measured number falls inside the stated range.
By their numbers in this assay, from the lowest: compounds 2 and 3 (each within the scatter of the next); then compound 1.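

In this assay the step of a 1.2-fold higher number from compound 2 to compound 3 (0.07 log units; within the scatter) leaves dimethylamino and methoxy on this aromatic carbon indistinguishable. With a 9.8-fold lower number from compound 1 to compound 3 (0.99 log units; beyond the scatter) as well, the distance from bromo no longer rests on methoxy alone, since two different groups now stand apart from it. Nothing available explains this result.

Still open, going by these compounds, is whether a smaller group such as fluoro or hydroxyl on this carbon would fall with bromo or with the other two. A primary amine or a carboxylic acid at the same place also remains to be placed.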